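Aryl variation on the anilino nitrogen: working notes toward compound 4

The source may report more compounds than this note shows. Statements on the series, on what has been measured and on what is new or still open speak of the compounds shown alone.

Measured so far:
compound 1 `COc1cc(NC(=O)Nc2cc(Nc3ccc(C(C)(C)C)cc3)ncn2)cc(OC)c1` — 17.5%
compound 2 `CCc1ccc(Nc2cc(NC(=O)Nc3cc(OC)cc(OC)c3)ncn2)cc1` — 23.5%
compound 3 `COc1cc(NC(=O)Nc2cc(Nc3cccc(C(C)(C)C)c3)ncn2)cc(OC)c1` — 13.1%

In a functional assay on NCI-H520 cells (Homo sapiens) for inhibition, read by MTT assay, with a stated time of 48 h, tested at 10 uM (on this read-out lower numbers stand for less inhibition and higher numbers for more inhibition at the one concentration tested (going by the name of the read-out)), compound 3 gives 13.1%, the lowest of the three numbers. Its nearest neighbour is compound 1, by a number 4.4 percentage points lower from compound 1 to compound 3 (within the scatter), and its furthest is compound 2, by a number 10.4 percentage points lower from compound 2 to compound 3 (beyond the scatter). The shared core is the same throughout; only the phenyl on the nitrogen on the aromatic ring varies, and across that variation the whole set of numbers sits in a narrow band.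

Compound 4 `COc1cc(NC(=O)Nc2cc(Nc3ccc(F)c(Cl)c3)ncn2)cc(OC)c1` is not yet measured. The change from compound 3 is 3-chloro-4-fluorophenyl in place of 3-(tert-butyl)phenyl on a nitrogen on an aromatic ring.

For the measured compounds named here, no measured step exchanges an alkylated phenyl for a halogenated one, so none bears on this change directly. The steps that come closest all rearrange or resize the substituent on the same phenyl: a number 4.4 percentage points lower from compound 1 to compound 3 (within the scatter), a number 6 percentage points higher from compound 1 to compound 2 (within the scatter) and a number 10.4 percentage points lower from compound 2 to compound 3 (beyond the scatter). Two of them lie within the scatter and the third is only modest. On this basis compound 4 is expected to stay in the same low band, with a step of a number 4.9 percentage points higher from compound 3 to compound 4 (within the scatter) that is not expected to exceed the scatter. The estimate for compound 4 in this assay is 18%, within 5% to 32%.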

Compound 4, a percentage reported as inhibition, at one concentration (the size of the read-out at that concentration, not a potency): 25.5%
Compound 4: middle estimate off by 7.5 percentage points, on the low side; the measured number falls inside the stated range.
By their numbers in this assay, from the lowest: compounds 3, 1, 2 and 4 (each within the scatter of the next, the first and the last beyond it).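

For the compounds shown here, the halogenated aryl is the first on this nitrogen to show that the group can be exchanged for an alkylated phenyl with a step beyond the scatter: in this assay, 3-chloro-4-fluorophenyl in place of 3-(tert-butyl)phenyl gives a number 12.4 percentage points higher from compound 3 to compound 4 (beyond the scatter). That separation does not extend to the other alkylated phenyls, since 3-chloro-4-fluorophenyl in place of 4-ethylphenyl gives a number 2 percentage points higher from compound 2 to compound 4 (within the scatter) and in place of 4-(tert-butyl)phenyl gives a number 8 percentage points higher from compound 1 to compound 4 (within the scatter), so the halogenated aryl stands apart only from 3-(tert-butyl)phenyl and all four aryl groups still sit in one low band. Nothing available on the series explains why this exchange separates from compound 3 and not from the other two.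

Going by these compounds alone, it remains open whether chlorine or fluorine alone would match the pair on this phenyl, since the single halogenated example changes both at once. Also unresolved is whether a phenyl carrying an amine, a carboxylic acid or a longer alkoxy chain on this nitrogen would lift the number out of the band at all.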